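Capping the phenol oxygen of compound 1 with isopropyl

A few compounds are considered here, and "the series" means these few. Any claim that something is new, unique, unknown or untested is made for them only; others in the source may bear on it.

Compound 1 `O=C(/C=C/c1ccc(O)c(O)c1)c1ccc(O)cc1` was measured in an assay on RBL-1 cells for inhibition of Polyunsaturated fatty acid 5-lipoxygenase (Rattus norvegicus) (on this read-out lower numbers stand for stronger inhibition and higher numbers for weaker inhibition), and gives 4 nM. Going by the values given here, of the two numbers in hand this is the lower one; the only other measured member, compound 2 `COc1cc(/C=C/C(=O)c2ccccc2O)ccc1O`, gives 17000 nM in this assay, a difference well beyond the scatter. Compound 2 differs from compound 1 in more than one place, so no single-point step can be read from that pair.

Compound 3 `CC(C)Oc1ccc(C(=O)/C=C/c2ccc(O)c(O)c2)cc1` has not yet been measured. Its difference from compound 1 is a single one: isopropyl in place of hydrogen on an oxygen on an aromatic ring. The two hydroxy groups on the other aromatic ring of compound 1 are kept unchanged in compound 3.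

Among the compounds with values here, with no step between measured compounds to lean on, the expectation rests on compound 1 alone. Since compound 1 gives 4 nM, compound 3 is expected to remain on the potent side of the series, but a modest loss is judged more likely than a gain, so the step of a 7.5-fold higher number from compound 1 to compound 3 (0.88 log units; beyond the scatter) is estimated as a small rise in this assay. Compound 3 is accordingly estimated at 30 nM, with a range from 5 nM to 300 nM.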

Compound 3, half-maximal inhibitory concentration: 41 nM
The estimate for compound 3 lay 1.4-fold (0.14 log units) below the measured number, within the range that was stated.
By their numbers in this assay, from the lowest: compound 1; then compound 3; then compound 2.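

In this assay, going by these compounds alone, the change from hydroxy to isopropoxy on this aromatic ring gives a 10-fold higher number from compound 1 to compound 3 (1.01 log units; beyond the scatter) and provides the first single-place step that can be read. The hydrogen on this oxygen therefore matters to the potency of compound 1, but replacing it with isopropyl does not abolish inhibition: compound 3 gives 41 nM with the two hydroxy groups on the other aromatic ring unchanged. The data give no measured basis for explaining the rise in the number, so the step stands as an observation only.

On these data alone, it remains open whether the loss follows from capping this oxygen at all or is specific to isopropyl, a question that methoxy or a longer chain such as butoxy on the same oxygen would address. As far as these compounds go, the contribution of the two hydroxy groups on the other aromatic ring also remains open, and replacing either one with an amine or a carboxylic acid on the core of compound 1 would give a single-place step there.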